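Trimming the Tertiary Amide: Pyrrolidine to Dimethylamine

The source may hold more compounds than are shown below. What is called first, only, known or untested is meant among the compounds shown, and "the series" means these compounds.

Measured compounds:
compound 1, `CN1CCN(C(=O)[C@@H]2C[C@H](S(=O)(=O)c3ccccc3)C[C@H]2C(=O)NC2(C#N)CC2)CC1`, 2 nM
compound 2, `N#CC1(NC(=O)[C@@H]2C[C@@H](S(=O)(=O)c3ccccc3)C[C@H]2C(=O)Nc2ccc(F)cc2)CC1`, 26 nM
compound 3, `N#CC1(NC(=O)[C@@H]2C[C@@H](S(=O)(=O)c3ccccc3)C[C@H]2C(=O)N2CCCC2)CC1`, 2 nM

All three share one core and differ only in the group carried on one carbonyl carbon, and all were read in an assay on isolated protein for inhibition of cathepsin S (Homo sapiens), read by fluorescence, with a stated time of 20 min; on this read-out lower numbers stand for stronger inhibition and higher numbers for weaker inhibition. Compound 3 stands level with compound 1 at the digits shown, and together they hold the two lowest numbers of the set; the one number apart belongs to compound 2, as a 13-fold lower number from compound 2 to compound 3 (1.11 log units; beyond the scatter) shows. Among the measured compounds shown here, compound 4, `CN(C)C(=O)[C@@H]1C[C@H](S(=O)(=O)c2ccccc2)C[C@H]1C(=O)NC1(C#N)CC1`, keeps the rest of compound 3 and changes only that group: dimethylamino in place of pyrrolidin-1-yl on a carbonyl carbon. For the measured compounds named here, two measured steps bear on this place. Exchanging one tertiary amide for another, no change at the digits printed from compound 1 to compound 3 (within the scatter), left the number where it was, whereas moving to an aromatic secondary amide, a 13-fold higher number from compound 1 to compound 2 (1.11 log units; beyond the scatter), moved it a long way. Since compound 4 again carries a tertiary amide, the step is expected to stay within the scatter: a 1.5-fold higher number from compound 3 to compound 4 (0.18 log units; within the scatter). For compound 4 the estimate in this assay is therefore 3 nM, with a range from 1 nM to 10 nM.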

Compound 4, half-maximal inhibitory concentration: 6 nM
Compound 4: middle estimate off by 2.0-fold (0.30 log units), on the low side; the range from low to high includes it.
By their numbers in this assay, from the lowest: compounds 1 and 3 (each within the scatter of the next); then compound 4; then compound 2.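

In this assay the tertiary amides at this carbonyl carbon do not all read alike: 4-methylpiperazin-1-yl and pyrrolidin-1-yl could not be told apart, yet dimethylamino, which has no ring, gives a 3.0-fold higher number from compound 3 to compound 4 (0.48 log units; beyond the scatter) and also a 3.0-fold higher number from compound 1 to compound 4 (0.48 log units; beyond the scatter) on the same read-out. It remains on the better side of the aromatic secondary amide, with a 4.3-fold lower number from compound 2 to compound 4 (0.64 log units; beyond the scatter) as the remaining step, so dimethylamino takes a level of its own, apart from both earlier ones. Nothing measured here accounts for these steps.

The compounds shown do not tell whether piperidin-1-yl or diethylamino on this carbonyl carbon would read with the ring-bearing amides or with dimethylamino. They also leave open how methylamino would read, which bears on whether the weaker number of compound 2 belongs to the amide hydrogen or to the 4-fluorophenyl group.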